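Three Oxime Ethers on SMMC-7721 Cells and a Fourth Expected

This account rests on a few compounds, and the source may have more. Where it says the series, first, only, none or still open, it means among the compounds named here.

Compound 1 `Clc1ccc(COc2ccccc2/C=C/C(/C=C/c2ccccn2)=N/Oc2ncnc3cc(Cl)ccc23)cc1`: 94.8%
Compound 2 `Fc1ccccc1COc1ccc(/C=C/C(/C=C/c2ccccn2)=N/Oc2ncnc3cc(Cl)ccc23)cc1`: 91.2%
Compound 3 `Clc1ccc(COc2ccc(/C=C/C(/C=C/c3cccs3)=N/Oc3ncnc4ccccc34)cc2)cc1`: 97.5%

All three compounds were tested in a functional assay on SMMC-7721 cells (Homo sapiens) for inhibition, read by MTT assay, with a stated time of 72 h, tested at 10 uM; a lower number here means a weaker effect, a higher number a stronger effect of the compound at the concentration tested. Compound 1 gives 94.8%, compound 2 gives 91.2% and compound 3 gives 97.5%. The number for compound 2 is the smallest of the three, but its gap to compound 1 and its gap to compound 3 both lie within the usual scatter of this kind of measurement, so the three compounds cannot be told apart on these numbers: each of them inhibits the cells strongly at the concentration tested.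

Compound 4 `Clc1ccc(COc2ccc(/C=C/C(/C=C/c3ccccn3)=N/Oc3ncnc4cc(Cl)ccc34)cc2)c(Cl)c1` has not yet been measured. It differs from compound 2 in one place: 2,4-dichlorophenyl in place of 2-fluorophenyl on a saturated chain carbon bound to an oxygen on an aromatic ring. Among the measured compounds shown here, the change concerns only the group on the saturated chain carbon bound to an oxygen on the aromatic ring, and no step between two measured compounds isolates such a change, so there is nothing to set its size from directly. For the measured compounds named here, since every compound measured so far sits near the top of the scale, no step beyond the scatter is expected in this assay; the step from compound 2 to compound 4 is estimated as a number 1.8 percentage points higher from compound 2 to compound 4 (within the scatter). Compound 4 is therefore expected to give about 93% in this assay, in a range from 82% to 99%.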

Compound 4, a percentage reported as inhibition, at one concentration (the size of the read-out at that concentration, not a potency): 23.6%
Compound 4: the middle estimate sits 69.4 percentage points above what was measured; the measured number lies below the stated range.
By their numbers in this assay, from the lowest: compound 4; then compounds 2, 1 and 3 (each within the scatter of the next).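

The exchange of 2-fluorophenyl for 2,4-dichlorophenyl on a saturated chain carbon bound to an oxygen on an aromatic ring gives a number 67.6 percentage points lower from compound 2 to compound 4 (beyond the scatter) in this assay, so the group carried at this place can decide whether a compound keeps its effect at the concentration tested. The earlier compounds shown here could not show this, as all of them sat near the top of the scale and no step between them isolated this place; the finding itself rests on this single pair. Nothing available here accounts for the size of the step.

The compounds shown leave open which part of the exchange carries the step, the loss of the fluorine or the gain of either chlorine, and a 2-chlorophenyl or a 4-chlorophenyl group on the core of compound 2 would separate these. They also leave open how other groups at this place would behave, such as a methoxyphenyl or an aminophenyl group, and whether the step would hold across a range of concentrations rather than at a single one.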